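A few compounds are considered here, and "the series" means these few. Any claim that something is new, unique, unknown or untested is made for them only; others in the source may bear on it.

Measured compounds:
- compound 1, `COc1ccc(/C=C/C(=O)NCc2ccc(OCc3nc(C)c(C)nc3C)c(OC)c2)cc1O`, 8560 nM
- compound 2, `COc1cc(CNC(=O)/C=C/c2ccc(OC)c(OCc3nc(C)c(C)nc3C)c2)ccc1OCc1nc(C)c(C)nc1C`, 11600 nM

Both numbers come from a functional assay on SH-SY5Y cells (Homo sapiens) for cytotoxicity, read by MTT assay, with stated times of 24 h and 4 h; on this read-out lower numbers stand for an effect already at smaller amounts and higher numbers for an effect only at larger amounts of compound. Compound 1 has the lowest of the two numbers; its nearest neighbour is compound 2, and the step of a 1.4-fold higher number from compound 1 to compound 2 (0.13 log units; within the scatter) lies within the scatter, so the two are indistinguishable on this read-out. That single step concerns the oxygen on the aromatic ring of the amide side and says nothing about the cinnamoyl-side ring.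

Compound 3, `COc1cc(CNC(=O)/C=C/c2cccc(OC)c2OC)ccc1OCc1nc(C)c(C)nc1C`, differs from compound 1 by 2,3-dimethoxyphenyl in place of 3-hydroxy-4-methoxyphenyl on a double-bonded chain carbon bound to a double-bonded chain carbon. Among the compounds with values here, no measured step covers this change. Within the data shown here, the only step available, from compound 1 to compound 2, was within the scatter, so the series so far shows a flat response to substitution on either ring. The expectation for compound 3 is therefore a step of a 1.1-fold higher number from compound 1 to compound 3 (0.05 log units; within the scatter) in this assay, not beyond the scatter. Compound 3 is estimated at 9500 nM, in the range 4000 nM to 22000 nM.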

Compound 3, half-maximal effective concentration: 7150 nM
Estimate against measurement, compound 3: 1.3-fold (0.12 log units) above; the range from low to high includes it.
By their numbers in this assay, from the lowest: compounds 3, 1 and 2 (each within the scatter of the next).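

In this assay, within the data shown here, 2,3-dimethoxyphenyl in place of 3-hydroxy-4-methoxyphenyl on a double-bonded chain carbon bound to a double-bonded chain carbon gives a 1.2-fold lower number from compound 1 to compound 3 (0.08 log units; within the scatter) and thereby supplies the first reading at this position, which the earlier step did not touch. The exchange leaves no hydrogen-bond donor in the group, yet the read-out does not separate the two compounds, so for this pair the loss of that donor and the added carbon come with no measurable change. Nothing available explains this result or bears on a property of either group.

Every aromatic substituent shown is attached through oxygen, so whether an amine or a carboxylic acid at this position would give a step beyond the scatter remains open. Equally open, going by these compounds, is what a longer chain in place of a methoxy group would do.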